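This account rests on a few compounds, and the source may have more. Where it says the series, first, only, none or still open, it means among the compounds named here.

Measured compounds:
- compound 1, `COC(=O)c1c(Nc2ccc(F)cc2)sc(C(=O)c2ccc(OC)cc2)c1C`: 18.2%
- compound 2, `COc1ccc(C(=O)c2sc(Nc3ccc(C)cc3)c(C(=O)O)c2C)cc1`: "not active" (no number reported)

In a functional assay, with a stated time of 150 min, tested at 20 ug/mL (on this read-out lower numbers stand for a weaker effect and higher numbers for a stronger effect at the one concentration tested), compound 1 gives 18.2%. In this assay compound 2 is reported as "not active" (no number reported), with no number behind it, so compound 2 stands at the inactive end of the read-out and cannot be placed on a scale against compound 1. Compound 1 and compound 2 differ in more than one place, so their two values only show that one gives a modest response and the other none.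

Compound 3, `COc1ccc(C(=O)c2sc(Nc3ccc(F)cc3)c(C(=O)O)c2C)cc1`, has not yet been tested. It is built from compound 2 by one change: fluoro in place of methyl on an aromatic carbon. Among the measured compounds shown here, no measured pair with this same change exists here, so the size of the step cannot be read from the data. The expectation is a step in this assay that is small, most likely none beyond the scatter, with a slight lean toward a stronger effect. Compound 3 is therefore estimated at 8%, with a range from 0% to 22%.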

Compound 3, a percentage reported as activity, at one concentration (the size of the read-out at that concentration, not a potency): 3.58%
Estimate against measurement, compound 3: 4.4 percentage points above, and the stated range covers the measured number.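

In this assay compound 3 gives 3.58% where compound 2 is recorded as "not active" (no number reported) with no number behind it, so the change from 4-methylphenyl to 4-fluorophenyl cannot be read as a step, and all that can be said is that the fluoro compound returns a number. Among the compounds shown here, the result does add the first step that can be read, with the (4-fluorophenyl)amino group held constant: hydrogen in place of methyl on an oxygen, which turns the methyl ester into the carboxylic acid, gives a number 14.6 percentage points lower from compound 1 to compound 3 (beyond the scatter) and so shows that, in this one pair, the methyl ester reads higher than the free acid. Nothing available explains why these two compounds differ in this way.

One pair cannot show whether the same drop would appear with the 4-methylphenyl group in place of the 4-fluorophenyl group, so the ester and acid pair stands for that single case only. From the compounds shown here alone, how a primary amide or an ethyl ester in place of the carboxylic acid would read, or chloro in place of fluoro on the aromatic ring, remains open.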